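The source may report more compounds than this note shows. Statements on the series, on what has been measured and on what is new or still open speak of the compounds shown alone.

- Compound 1 `Cn1c(=O)c(S(=O)(=O)c2ccc(Cl)cc2Cl)cc2cnc(Nc3ccc4[nH]ccc4c3)nc21`: 1000 nM
- Compound 2 `Cn1ccc2cc(Nc3ncc4cc(S(=O)(=O)c5ccc(F)cc5F)c(=O)n(C)c4n3)ccc21`: 750 nM

In a functional assay on K562 cells (Homo sapiens) for inhibition, read by trypan blue exclusion, with a stated time of 72 h (a lower number here means a stronger inhibitor, a higher number a weaker inhibitor), compound 2 gives 750 nM, which lies within the usual scatter of compound 1 at 1000 nM. Within the data shown here, no measured pair isolates a single structural change. Compound 3 `Cn1ccc2cc(Nc3ncc4cc(S(=O)(=O)c5ccc(Cl)cc5Cl)c(=O)n(C)c4n3)ccc21` has not yet been measured and differs from compound 2 as follows: 2,4-dichlorophenyl in place of 2,4-difluorophenyl on a sulfonyl sulfur. This places 2,4-dichlorophenyl in place of 2,4-difluorophenyl on a sulfonyl sulfur. No change beyond the scatter is expected in this assay. The estimated step is a 1.1-fold lower number from compound 2 to compound 3 (0.03 log units; within the scatter). For compound 3, the expected value is 700 nM, with an estimated range of 250 nM to 2000 nM.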

Compound 3, half-maximal inhibitory concentration: 750 nM
For compound 3 the middle estimate is 1.1-fold (0.03 log units) below the measured one; low and high end bracket the measured number.
By their numbers in this assay, from the lowest: compounds 2, 3 and 1 (each within the scatter of the next).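

In this assay, 2,4-dichlorophenyl in place of 2,4-difluorophenyl on the sulfonyl sulfur gives no change at the digits printed from compound 2 to compound 3 (within the scatter), so exchanging these two halogen pairs at this position leaves the number unchanged. Methyl in place of hydrogen on an aromatic nitrogen, with the 2,4-dichlorophenyl group kept, gives a 1.3-fold lower number from compound 1 to compound 3 (0.12 log units; within the scatter), so this change also stays within the scatter. No supporting data bear on these results.

Still open, going by these compounds, is whether an amine on the phenyl ring, or cyclohexyl in its place, would shift the number beyond the scatter. An ethyl chain on that aromatic nitrogen also remains an open question.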